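Moving the Pyridine Nitrogen: A Comparison Bounded by Limits

A few compounds are considered here, and "the series" means these few. Any claim that something is new, unique, unknown or untested is made for them only; others in the source may bear on it.

In a functional assay on CHO cells for agonist activity at Alpha-2B adrenergic receptor (Homo sapiens) (a higher number here means a larger maximal response, a lower number a smaller maximal response), compound 1 `CC(Oc1ccccc1-c1ccc([N+](=O)[O-])cc1)C1=NCCN1` gives < 0.3, which is a limit of the assay rather than a measured number. Compound 2 `CC(Oc1ccccc1-c1ccncc1)C1=NCCN1` gives < 0.3 in this assay, again only a limit. Both values sit at the limit of < 0.3 in this assay, at which 2 of the 2 values shown sit. Compound 3 `CC(Oc1ccccc1-c1ccccn1)C1=NCCN1` has not been measured; it differs from compound 2 by pyridin-2-yl in place of pyridin-4-yl on an aromatic carbon. Among the compounds with values here, no measured step links the two, so the step that the limit leaves unreadable from compound 2 to compound 3 is expected to be no larger than the usual scatter. Compound 3 is therefore estimated to reach 0.2, between 0.05 and 0.4, and is likely to be reported again only as a limit.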

Compound 3, intrinsic activity: the largest response reached, as a fraction of the reference agonist's: < 0.3
Compound 3 was reported as a limit (the forecaster's own chance of this, stated with the estimate: 70%); the middle value does not contradict the limit.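

Within the data shown here, compound 2 and compound 3 are both reported only as limits, so no step between them can be read: the limit of < 0.3 in this assay, at which 3 of the 3 values shown sit. The compounds shown leave open whether pyridin-2-yl and pyridin-4-yl differ at all in this assay above that limit.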